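Ethyl on the chain of compound 1: an expected small step

A few compounds are considered here, and "the series" means these few. Any claim that something is new, unique, unknown or untested is made for them only; others in the source may bear on it.

Measured in a functional assay on B16-F10 cells (Mus musculus) for antiproliferative activity, read by MTT assay, with a stated time of 72 h; a lower number here means a stronger inhibitor, a higher number a weaker inhibitor:
compound 1 `CCCCCCCNC[C@@H]1OC[C@H](N)[C@@H]1O` gives > 128000 nM
compound 2 `CCCCCCCNC[C@@H]1OC[C@H](N)[C@H]1O` gives > 128000 nM
compound 3 `CCCCCCCCCCCNC[C@@H]1OC[C@H](N)[C@H]1O` gives 88800 nM

Compound 1 has no number of its own, and its entry of > 128000 nM is a limit. Compound 2 gives > 128000 nM, which is likewise a limit. The series therefore rests largely on (the limit of > 128000 nM in this assay, at which 2 of the 3 values shown sit), and only compound 3 gives a true number.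

Compound 4 `CCCCCCCCCNC[C@@H]1OC[C@H](N)[C@@H]1O` keeps the configuration of compound 1 and differs from it by ethyl in place of hydrogen on a saturated chain carbon, seven bonds along the chain from an amine nitrogen. This is ethyl in place of hydrogen on a saturated chain carbon, seven bonds along the chain from an amine nitrogen.

For the measured compounds named here, two measured steps bear on this change. Going by the values given here, the first is a step that the two limits leave unreadable from compound 1 to compound 2, so the effect of configuration stays unknown despite (the fact that compounds 1 and 2 differ only in the configuration as drawn). The second, closer in kind, is an at least 1.4-fold lower number from compound 2 to compound 3 (0.15 log units; that floor lies within the scatter), and it was taken on the configuration of compound 2. Neither step supports a large change, so only a small move towards a lower number is expected, and compound 4 may again return only a limit. The expected step is an at least 1.1-fold lower number from compound 1 to compound 4 (0.06 log units; that floor lies within the scatter). Compound 4 is estimated at 110000 nM, with an expected range from 50000 nM to 200000 nM.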

Compound 4, half-maximal inhibitory concentration: 55200 nM
Beside the measured number, compound 4's estimate is 2.0-fold (0.30 log units) above it; measured number inside the range.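

In this assay, for the compounds shown here, ethyl on a saturated chain carbon, seven bonds along the chain from an amine nitrogen, gives an at least 2.3-fold lower number from compound 1 to compound 4 (0.36 log units; beyond the scatter), which is the first step readable as lying beyond the scatter. Compound 1 has an entry of > 128000 nM, which is a limit, and the step taken from it is therefore a floor and not a full size. Going by these compounds alone, compound 4 also supplies the first true number on the configuration of compound 1, whereas the earlier lengthening of the chain, on the configuration of compound 2, gave an at least 1.4-fold lower number from compound 2 to compound 3 (0.15 log units; that floor lies within the scatter).

The effect of configuration remains unreadable, as the step between the two configurations cannot be read and the series still leans heavily on one assay limit: the limit of > 128000 nM in this assay, at which 2 of the 4 values shown sit. On these data alone, whether a longer chain on the configuration of compound 1 would lower the number further, or whether an amine or a carboxylic acid at the end of the chain would keep this gain, stays open.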